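The source may report more compounds than this note shows. Statements on the series, on what has been measured and on what is new or still open speak of the compounds shown alone.

Measured so far in a functional assay on the whole organism for inhibition, with Rattus norvegicus as the target, read by paw edema, with stated times of 30 min and 5 h, at a dose of 0.28 mmol/kg by the oral route; on this read-out higher numbers stand for more inhibition at the one dose given (going by the name of the read-out) and lower numbers for less inhibition:
Compound 1 `CCNC(=O)c1nc(-c2cc(OC)c(OC)c(OC)c2)n(-c2ccc(OC)cc2)n1`: 52%
Compound 2 `COc1ccc(-n2nc(C(=O)Nc3cccc(F)c3)nc2-c2cc(OC)c(OC)c(OC)c2)cc1`: 53%
Compound 3 `COc1ccc(-n2nc(C(=O)Nc3ccc(C(=O)O)cc3)nc2-c2cc(OC)c(OC)c(OC)c2)cc1`: 60%

On the numbers shown, compound 3 sits at the top of the three, but the separation is not real: a number 7 percentage points higher from compound 2 to compound 3 (within the scatter) and a number 8 percentage points higher from compound 1 to compound 3 (within the scatter) are both within the scatter, as is a number 1 percentage points higher from compound 1 to compound 2 (within the scatter). The three compounds are therefore not distinguished by this assay.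

Compound 4 `COc1ccc(-n2nc(C(=O)Nc3ccc(O)cc3)nc2-c2cc(OC)c(OC)c(OC)c2)cc1` is the next member. Relative to compound 3 it differs in one place: hydroxy in place of carboxy on an aromatic carbon.

All three measured steps swap the whole group on the amide-type nitrogen, from ethyl to 3-fluorophenyl or to 4-carboxyphenyl, and none of them moved the number beyond the scatter. Within the data shown here, no measured step exchanges one substituent for another on the aromatic ring while keeping the ring, so the change into compound 4 has no direct precedent. Given that even the larger swaps left the read-out flat, the change from carboxy to hydroxy is expected to do the same, with no step beyond the scatter in either direction.

Compound 4 is therefore expected to give about 56%, estimated to fall between 44% and 68%. The step of a number 4 percentage points lower from compound 3 to compound 4 (within the scatter) that this estimate implies is expected to lie within the scatter.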

Compound 4, a percentage reported as inhibition, in the whole organism at one dose (the size of the read-out at that dose, not a potency): 27%
Compound 4: middle estimate off by 29 percentage points, on the high side; the whole stated range lies above it.
By their numbers in this assay, from the lowest: compound 4; then compounds 1, 2 and 3 (each within the scatter of the next).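

In this assay, among these compounds, the group on the amide-type nitrogen is no longer silent: a number 33 percentage points lower from compound 3 to compound 4 (beyond the scatter) is the first step beyond the scatter, and it comes from a change confined to one substituent, hydroxy in place of carboxy on an aromatic carbon, para to a large group. The other two steps point the same way, a number 26 percentage points lower from compound 2 to compound 4 (beyond the scatter) and a number 25 percentage points lower from compound 1 to compound 4 (beyond the scatter), so the flat picture across ethyl, 3-fluorophenyl and 4-carboxyphenyl does not extend to 4-hydroxyphenyl, and the read-out at this position is sensitive to the substituent on the ring as well as to the group as a whole. Nothing in the available data offers an explanation for this fall.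

The compounds shown leave open whether the low number is particular to hydroxy, a question that methoxy, an amine or a methyl ester at the same place on the ring would help to settle. With one dose and one read-out, they also leave open whether the difference between the 4-carboxyphenyl and 4-hydroxyphenyl amides would hold at other doses.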